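Amide aryl variation on the shared core: outlook for compound 4

The source may hold more compounds than are shown below. What is called first, only, known or untested is meant among the compounds shown, and "the series" means these compounds.

Measured so far, in a functional assay on 143B cells (Homo sapiens) for antiproliferative activity, read by MTT assay, with a stated time of 48 h; on this read-out lower numbers stand for stronger inhibition and higher numbers for weaker inhibition:
compound 1 `O=C(/C=C/c1cccc(NC(=O)c2ccccc2Cl)c1)c1nc2ccccc2[nH]1` gives 3690 nM
compound 2 `O=C(Nc1cccc(/C=C/C(=O)c2nc3ccccc3[nH]2)c1)c1ccc(Cl)cc1` gives 7440 nM
compound 3 `O=C(Nc1cccc(/C=C/C(=O)c2nc3ccccc3[nH]2)c1)c1ccc(Br)cc1` gives 7310 nM

Compound 3 holds the second highest of the three numbers in this assay, with compound 2 nearest and compound 1 furthest, all differences within the scatter. Compound 4 `O=C(Nc1cccc(/C=C/C(=O)c2nc3ccccc3[nH]2)c1)c1cccc(C(F)(F)F)c1` carries the change (3-(trifluoromethyl)phenyl in place of 4-bromophenyl on a carbonyl carbon). For the measured compounds named here, the steps that bear on it are a 2.0-fold higher number from compound 1 to compound 2 (0.30 log units; within the scatter), a 2.0-fold higher number from compound 1 to compound 3 (0.30 log units; within the scatter) and a 1.0-fold lower number from compound 2 to compound 3 (0.01 log units; within the scatter): every aryl amide exchange made so far moved the number little. Going by the values given here, no measured step exchanges a halogen for a trifluoromethyl group, so the expectation rests on the small size of the steps seen; no step beyond the scatter is expected in this assay. Compound 4 is estimated at 6000 nM, between 2500 nM and 15000 nM, an expected step of a 1.2-fold lower number from compound 3 to compound 4 (0.09 log units; within the scatter).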

Compound 4, half-maximal inhibitory concentration: 9570 nM
For compound 4 the middle estimate is 1.6-fold (0.20 log units) below the measured one; the range from low to high includes it.
By their numbers in this assay, from the lowest: compounds 1, 3, 2 and 4 (each within the scatter of the next, the first and the last beyond it).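

In this assay, 3-(trifluoromethyl)phenyl on a carbonyl carbon is not separated from the 4-halophenyl amides: a 1.3-fold higher number from compound 3 to compound 4 (0.12 log units; within the scatter) and a 1.3-fold higher number from compound 2 to compound 4 (0.11 log units; within the scatter). Against the 2-chlorophenyl amide, however, the exchange gives the only step in the series that passes the scatter, a 2.6-fold higher number from compound 1 to compound 4 (0.41 log units; beyond the scatter). No measurement on hand accounts for that modest step.

On these data alone, an amine or a carboxylic acid in place of the halogen or trifluoromethyl group remains open. So does 4-(trifluoromethyl)phenyl, which would separate the identity of the group from its placement on the ring.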